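A fluorinated swap from the lowest number so far

The source may hold more compounds than are shown below. What is called first, only, known or untested is meant among the compounds shown, and "the series" means these compounds.

In a functional assay on A549 cells (Homo sapiens) for antiproliferative activity, read by MTT assay, with a stated time of 72 h (on this read-out higher numbers stand for weaker inhibition and lower numbers for stronger inhibition), compound 1 `CCCNC(=O)c1cc(Oc2ccc(NC(=O)c3nn(-c4ccc(Br)cc4F)c(=O)cc3C)cc2F)ccn1` gives 235000 nM, compound 2 `CCCNC(=O)c1cc(Oc2ccc(NC(=O)c3nn(-c4ccccc4C)c(=O)cc3C)cc2F)ccn1` gives 25700 nM and compound 3 `CCCNC(=O)c1cc(Oc2ccc(NC(=O)c3nn(-c4ccccc4OC(F)(F)F)c(=O)cc3C)cc2F)ccn1` gives 4220 nM, the lowest of the three numbers and so the strongest inhibition. Compound 4 `CCCNC(=O)c1cc(Oc2ccc(NC(=O)c3nn(-c4cccc(C(F)(F)F)c4)c(=O)cc3C)cc2F)ccn1` carries 3-(trifluoromethyl)phenyl in place of 2-(trifluoromethoxy)phenyl on an aromatic nitrogen. Earlier changes at this same place moved the number well beyond the scatter: a 9.1-fold lower number from compound 1 to compound 2 (0.96 log units; beyond the scatter), a 6.1-fold lower number from compound 2 to compound 3 (0.78 log units; beyond the scatter) and a 56-fold lower number from compound 1 to compound 3 (1.75 log units; beyond the scatter). None of these compounds carries a trifluoromethyl group, so these steps show how far the number can move, not which way it will go here. In this assay a modest step to a higher number is therefore expected, a 2.8-fold higher number from compound 3 to compound 4 (0.45 log units; beyond the scatter). For compound 4 the estimate is 12000 nM, with an expected range of 3000 nM to 50000 nM.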

Compound 4, half-maximal inhibitory concentration: 9240 nM
Compound 4: middle estimate off by 1.3-fold (0.11 log units), on the high side; low and high end bracket the measured number.
By their numbers in this assay, from the lowest: compound 3; then compound 4; then compound 2; then compound 1.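

Replacing 2-(trifluoromethoxy)phenyl with 3-(trifluoromethyl)phenyl costs some activity in this assay (a 2.2-fold higher number from compound 3 to compound 4 (0.34 log units; beyond the scatter)), so compound 3 keeps the lowest number. Even so, 3-(trifluoromethyl)phenyl outperforms 2-methylphenyl (a 2.8-fold lower number from compound 2 to compound 4 (0.44 log units; beyond the scatter)) and 4-bromo-2-fluorophenyl (a 25-fold lower number from compound 1 to compound 4 (1.41 log units; beyond the scatter)), showing that this place tolerates a group named at the 3 position as well as those named at the 2 position. No supporting data here explain this order. Still open, going by these compounds, is whether the trifluoromethyl group or its place on the phenyl ring sets the number, and how an amine or a carboxylic acid on that ring would behave.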